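Sulfamoyl in place of nitro on a shared core

This account rests on a few compounds, and the source may have more. Where it says the series, first, only, none or still open, it means among the compounds named here.

Measured so far:
compound 1, `O=C(O)c1ccc(CNS(=O)(=O)c2ccc3c(c2)cc(C(=O)O)n3Cc2ccc(C(=O)O)cc2)cc1`: 100%
compound 2, `O=C(O)c1ccc(Cn2c(C(=O)O)cc3cc([N+](=O)[O-])ccc32)cc1`: 61%

In an assay on cells (Oocyte) for inhibition of pannexin-1 (Mus musculus), read by voltage clamp, tested at 50 uM, in the presence of a further agent that is not named here (a higher number here means more inhibition at the concentration tested (going by the name of the read-out), a lower number less inhibition), compound 1 gives 100% and compound 2 gives 61%. Compound 2 thus stands lowest of the two, with its nearest neighbour, compound 1, lying higher by a gap beyond the usual scatter. The next compound, compound 3 `NS(=O)(=O)c1ccc2c(c1)cc(C(=O)O)n2Cc1ccc(C(=O)O)cc1`, has not yet been measured. It differs from compound 2 in one place: sulfamoyl in place of nitro on an aromatic carbon. Going by the values given here, no measured pair shows a change of this kind, so the size of the step cannot be read off and has to be expected. Compound 2 gives 61% and compound 1 gives 100%, and compound 3 is expected to land between these two. The step of a number 14 percentage points higher from compound 2 to compound 3 (beyond the scatter) is expected to be a moderate rise, around the edge of the scatter. Compound 3 is estimated at 75% in this assay, with a range from 50% to 95%.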

Compound 3, a percentage reported as inhibition, at one concentration (the size of the read-out at that concentration, not a potency): 61.7%
Estimate against measurement, compound 3: 13.3 percentage points above; low and high end bracket the measured number.
By their numbers in this assay, from the lowest: compounds 2 and 3 (each within the scatter of the next); then compound 1.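

In this assay, the exchange of nitro for sulfamoyl on this aromatic carbon gives a step (a number 0.7 percentage points higher from compound 2 to compound 3 (within the scatter)), so the two groups cannot be told apart here at the concentration tested. The sulfonamide nitrogen reads differently: hydrogen in place of 4-carboxybenzyl there gives a large step (a number 38.3 percentage points lower from compound 1 to compound 3 (beyond the scatter)), so the higher reading of compound 1 goes with the 4-carboxybenzyl group and not with the sulfonamide link alone. Nothing measured here explains either result.

As far as these compounds go, it remains open whether a methyl or an unsubstituted benzyl on that nitrogen would keep the higher reading of compound 1. Also open, from the compounds shown here alone, is whether an amine or a nitrile on the aromatic carbon would read as nitro and sulfamoyl do.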